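Amide variation on a chloro-substituted core: morpholine to propylamine

The source may hold more compounds than are shown below. What is called first, only, known or untested is meant among the compounds shown, and "the series" means these compounds.

Measured so far:
compound 1 `Cc1c(C(=O)N2CCOCC2)oc2ccc(Nc3ncnc4ccc(Cl)nc34)cc12` — > 10000 nM
compound 2 `O=C(c1cccc(C#Cc2ccccc2Nc2ncnc3ccc(Cl)nc23)c1)N1CCNCC1` — > 10000 nM

Both entries in an assay on isolated protein for inhibition of MAP kinase-interacting serine/threonine-protein kinase 1 (Homo sapiens), read by HTRF, in the presence of a further agent that is not named here (on this read-out lower numbers stand for stronger inhibition and higher numbers for weaker inhibition), are limits of the assay rather than numbers. Compound 1 returns only the limit > 10000 nM in this assay. Compound 2 likewise returns only the limit > 10000 nM in this assay. Compound 1 therefore stands at the boundary of what this assay reports, with no measurable inhibition to rank it against anything, and the two compounds share the same standing: the limit of > 10000 nM in this assay, at which 2 of the 2 values shown sit.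

The unmeasured compound 3 `CCCNC(=O)c1oc2ccc(Nc3ncnc4ccc(Cl)nc34)cc2c1C` keeps the core of compound 1 and differs in one place: propylamino in place of morpholin-4-yl on a carbonyl carbon. The change replaces a ring amide with an open-chain amide carrying an amide hydrogen, and nothing in the values gathered here connects such a swap to a shift in this assay.

For the measured compounds named here, no step between measured compounds is available, and the starting point is itself a limit. The expectation for compound 3 is therefore no change beyond the scatter, with the step that the limit leaves unreadable from compound 1 to compound 3 expected to leave it at or near the limit. Compound 3 is estimated at 12000 nM in this assay, within 3000 nM to 40000 nM.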

Compound 3, half-maximal inhibitory concentration: > 10000 nM
Compound 3 ended at the assay's limit (the forecaster's own chance of this, stated with the estimate: 80%); the middle value is on the limit's open side.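

No step can be read between compound 1 and compound 3, with propylamino in place of morpholin-4-yl on a carbonyl carbon, because both rest on the same limit rather than a number: the limit of > 10000 nM in this assay, at which 3 of the 3 values shown sit.

The compounds shown leave open whether any amide on the shared core gives a measurable value in this assay and, if so, which one.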